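The compounds below may be only part of what the source reports. "The series", "measured", "known", "first", "only" and "open" are said of these compounds alone.

Compound 1, `CCC(CC)Nc1nc(C)nc2c(-c3c(C)cc(N(C)C)nc3C)c(C)nn12`: 25.6 nM
Compound 2, `CCC(CC)Nc1nc(C)nc2c(-c3cnc(N(C)C)cc3C)c(C)nn12`: 24.8 nM
Compound 3, `CCCN(CCC)c1nc(C)nc2c(-c3c(C)cc(N(C)C)nc3C)c(C)nn12`: 14.9 nM

Of the compounds shown here, three sharing one core have been measured in an assay on cell membranes for displacement of a labelled ligand from corticotropin-releasing factor receptor 1 (Rattus norvegicus); a higher number here means a weaker inhibitor, a lower number a stronger inhibitor. Compound 1 gives 25.6 nM. Compound 2 gives 24.8 nM, a change of a 1.0-fold lower number from compound 1 to compound 2 (0.01 log units; within the scatter). Compound 3 gives 14.9 nM, a change of a 1.7-fold lower number from compound 1 to compound 3 (0.24 log units; within the scatter); compound 3 has the lowest number of the three, yet its gaps to compound 1 and compound 2 both stay within the scatter, so no ordering can be read from them.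

Compound 4, `CCCCN(CC)c1nc(C)nc2c(-c3c(C)cc(N(C)C)nc3C)c(C)nn12`, has not yet been measured in this assay. It differs from compound 3 by butyl(ethyl)amino in place of dipropylamino on an aromatic carbon. Among the measured compounds shown here, the only step that touches the same place is the one from compound 1 to compound 3, a 1.7-fold lower number from compound 1 to compound 3 (0.24 log units; within the scatter), and that step is itself within the scatter. The change from compound 3 to compound 4 keeps the same atoms and only joins them differently, so no movement beyond the scatter is expected, and compound 4 is expected to show a step of a 1.1-fold higher number from compound 3 to compound 4 (0.03 log units; within the scatter). Compound 4 is therefore estimated at 16 nM, with a range from 7 nM to 36 nM.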

Compound 4, half-maximal inhibitory concentration: 32.8 nM
Compound 4: middle estimate off by 2.1-fold (0.31 log units), on the low side; the range from low to high includes it.
By their numbers in this assay, from the lowest: compounds 3, 2, 1 and 4 (each within the scatter of the next, the first and the last beyond it).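

At the aromatic carbon between two ring nitrogen atoms, butyl(ethyl)amino in place of dipropylamino keeps the same atoms and only joins them differently, yet in this assay it gives a 2.2-fold higher number from compound 3 to compound 4 (0.34 log units; beyond the scatter) as the only step among these compounds that lies beyond the scatter. The change is modest, but it shows that the way the chains are arranged at this position can be read in this measurement even when the atoms stay the same. Butyl(ethyl)amino in place of (pentan-3-yl)amino gives a 1.3-fold higher number from compound 1 to compound 4 (0.11 log units; within the scatter) and so sets no order between that pair.

Going by these compounds, it remains open how bis(2-methoxyethyl)amino or an amine carrying a cyclopropylmethyl group would read at this position. On these data alone, it is also open whether the step to butyl(ethyl)amino would hold on the core of compound 2.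

Nothing at hand explains the difference between the two chains.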